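The source may hold more compounds than are shown below. What is called first, only, known or untested is meant among the compounds shown, and "the series" means these compounds.

Measured so far:
compound 1 `COc1cc(-c2nn(-c3ccc(NC(=O)Nc4ccc(Cl)c(Cl)c4)cc3)cc2-c2ccncc2)ccc1Cl` — 2560 nM
compound 2 `COc1cc(-c2nn(-c3ccc(NC(=O)Nc4cc(C(F)(F)F)cc(C(F)(F)F)c4)cc3)cc2-c2ccncc2)ccc1Cl` — 1990 nM
compound 3 `O=C(Nc1ccc(-n2cc(-c3ccncc3)c(-c3ccc(Cl)c(O)c3)n2)cc1)Nc1ccc(Cl)c(C(F)(F)F)c1` — 1430 nM

All three numbers come from a functional assay on M14 cells (Homo sapiens) for antiproliferative activity, read by sulforhodamine B assay, with a stated time of 48 h; on this read-out lower numbers stand for stronger inhibition and higher numbers for weaker inhibition. Compound 2 sits in the middle of the three; the gap to compound 1 and the gap to compound 3 both fall within the usual scatter of repeated measurements, so on this read-out the three compounds cannot be told apart.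

Compound 4 `O=C(Nc1ccc(-n2cc(-c3ccncc3)c(-c3ccc(Cl)c(O)c3)n2)cc1)Nc1cc(C(F)(F)F)cc(C(F)(F)F)c1` is not yet measured. It differs from compound 2 by hydrogen in place of methyl on an oxygen on an aromatic ring: methoxy to hydroxy, 4-chloro-3-methoxyphenyl to 4-chloro-3-hydroxyphenyl. For the measured compounds named here, no pair of measured compounds shows this change alone. Compound 3 already carries the 4-chloro-3-hydroxyphenyl group, though with a different urea end, and its number lies within the scatter of both compound 1 and compound 2, which carry the methoxy. Nothing in the three values suggests that exchanging methoxy for hydroxy moves the read-out beyond the scatter, so the expected step of a 1.1-fold lower number from compound 2 to compound 4 (0.04 log units; within the scatter) is essentially none.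

Compound 4 is therefore estimated at 1800 nM in this assay, with an expected range from 800 nM to 4000 nM.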

Compound 4, half-maximal inhibitory concentration: 1760 nM
The estimate for compound 4 lay 1.0-fold (0.01 log units) above the measured number; measured number inside the range.
By their numbers in this assay, from the lowest: compounds 3, 4, 2 and 1 (each within the scatter of the next).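

In this assay the methoxy to hydroxy exchange gives a 1.1-fold lower number from compound 2 to compound 4 (0.05 log units; within the scatter). For the compounds shown here, this is the first pair that differs in one place only, so the exchange no longer has to be inferred from compounds with different urea ends. For this urea end and this position, a methyl on the oxygen on the aromatic ring can be replaced by hydrogen with no change that can be told apart on this read-out, and the 4-chloro-3-hydroxyphenyl and 4-chloro-3-methoxyphenyl groups cannot be separated here; no measurement is available that would explain this result.

The single pair leaves open whether the same holds with the other urea ends, and all four compounds lie within the scatter of their neighbours in the ranking, so no change shown so far is known to move the read-out. Also open, going by these compounds, is what a longer chain such as ethoxy on that oxygen, or an amine or a carboxylic acid at the same place, would do to the number.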